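Compound 3 to compound 4: hydroxymethyl for 2,2-difluoroethoxy

A few compounds are considered here, and "the series" means these few. Any claim that something is new, unique, unknown or untested is made for them only; others in the source may bear on it.

Compound 1 `O=C(CN1CC[C@@H](NC(=O)c2ccc(Cl)s2)C1)Nc1ccc(-n2ccccc2=O)cc1F`: 79.2 mL.min-1.g-1
Compound 2 `O=C(CN1C[C@H](NC(=O)c2ccc(Cl)s2)[C@@H](O)C1)Nc1ccc(-n2ccccc2=O)cc1F`: 15.8 mL.min-1.g-1
Compound 3 `O=C(CN1C[C@H](NC(=O)c2ccc(Cl)s2)[C@@H](OCC(F)F)C1)Nc1ccc(-n2ccccc2=O)cc1F`: 35 mL.min-1.g-1

All three values come from an in vitro ADME assay on microsomes (Rattus norvegicus) for metabolic stability; a lower number here means slower removal, a higher number faster removal of the compound. Compound 3 is second highest of the three, with compound 2 lower and compound 1 higher, both gaps beyond the scatter. Compound 4 `O=C(CN1C[C@H](CO)[C@@H](NC(=O)c2ccc(Cl)s2)C1)Nc1ccc(-n2ccccc2=O)cc1F` differs from compound 3 by hydroxymethyl in place of 2,2-difluoroethoxy on a saturated ring carbon.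

For the measured compounds named here, no measured compound carries hydroxymethyl, so the guidance is indirect. The nearest step is a 2.2-fold higher number from compound 2 to compound 3 (0.35 log units; beyond the scatter), which puts 2,2-difluoroethyl on the oxygen of a free hydroxy. Compound 4 returns a free hydroxy, though on an added carbon and at a different ring place. The steps of a 5.0-fold lower number from compound 1 to compound 2 (0.70 log units; beyond the scatter) and a 2.3-fold lower number from compound 1 to compound 3 (0.35 log units; beyond the scatter) show that both oxygen substituents sit below the unsubstituted compound 1. A modest fall is therefore expected, and the expected step is a 1.8-fold lower number from compound 3 to compound 4 (0.24 log units; within the scatter). In this assay the estimated value for compound 4 is 20 mL.min-1.g-1, with an expected range of 9 mL.min-1.g-1 to 42 mL.min-1.g-1.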

Compound 4, intrinsic clearance in microsomes: 35.4 mL.min-1.g-1
For compound 4 the middle estimate is 1.8-fold (0.25 log units) below the measured one; measured number inside the range.
By their numbers in this assay, from the lowest: compound 2; then compounds 3 and 4 (each within the scatter of the next); then compound 1.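

In this assay, hydroxymethyl in place of 2,2-difluoroethoxy on this saturated ring carbon gives a 1.0-fold higher number from compound 3 to compound 4 (0.00 log units; within the scatter), so these two groups are not told apart here despite their different sizes and the hydrogen-bond donor that hydroxymethyl brings. Hydroxymethyl still stands apart from the unsubstituted ring, with a 2.2-fold lower number from compound 1 to compound 4 (0.35 log units; beyond the scatter), but it does not match the directly attached hydroxy, with a 2.2-fold higher number from compound 2 to compound 4 (0.35 log units; beyond the scatter), so a free hydroxy alone does not set the number in this small set. The data offer no explanation for either difference.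

Compound 2 and compound 4 differ both in the added carbon and in the ring place of the oxygen-bearing group, and the effects of these two differences remain unseparated. As far as these compounds go, how an aminomethyl group, a carboxylic acid or a longer hydroxyalkyl chain would behave on this ring carbon also remains open.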